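From 2,5-dimethylphenyl to phenyl on compound 2

This account rests on a few compounds, and the source may have more. Where it says the series, first, only, none or still open, it means among the compounds named here.

Measured so far in a functional assay on HepG2 cells (Homo sapiens) for inhibition, with a stated time of 72 h; a higher number here means a weaker inhibitor, a lower number a stronger inhibitor:
- compound 1 (`COc1ccc(NC(=O)Nc2nc(Sc3c[nH]c4ccccc34)cc(N3CCN(c4ccccn4)CC3)n2)cc1`) gives 11400 nM
- compound 2 (`Cc1ccc(C)c(NC(=O)Nc2nc(Sc3c[nH]c4ccccc34)cc(N3CCCCC3)n2)c1`) gives 6440 nM
- compound 3 (`COc1ccc(NC(=O)Nc2nc(Sc3c[nH]c4ccccc34)cc(N3CCN(Cc4ccccc4)CC3)n2)cc1`) gives 21400 nM

Compound 2 lies within the usual scatter of compound 1, while compound 3 at 21400 nM stands beyond the scatter from it. Compound 4 (`O=C(Nc1ccccc1)Nc1nc(Sc2c[nH]c3ccccc23)cc(N2CCCCC2)n1`) differs from compound 2 in one place, with phenyl in place of 2,5-dimethylphenyl on an amide-type nitrogen and the rest unchanged.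

Among the measured compounds shown here, the only measured single-place step is a 1.9-fold higher number from compound 1 to compound 3 (0.27 log units; within the scatter) (benzyl in place of pyridin-2-yl on an amine nitrogen in a ring). That change lies elsewhere in the molecule, so it gives only a rough idea of step size and no direction. For the measured compounds named here, no measured pair isolates the group on the amide-type nitrogen. In this assay no step beyond the scatter is therefore expected, and the estimate starts from compound 2 at 6440 nM as its anchor. The expected change is small, a 1.2-fold higher number from compound 2 to compound 4 (0.07 log units; within the scatter) in the estimate. For compound 4 the estimated value is 7500 nM with an expected range from 3200 nM to 17000 nM in repeat measurements.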

Compound 4, half-maximal inhibitory concentration: 20900 nM
Compound 4: middle estimate off by 2.8-fold (0.45 log units), on the low side; the whole stated range lies below it.
By their numbers in this assay, from the lowest: compounds 2, 1, 4 and 3 (each within the scatter of the next, the first and the last beyond it).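

Among the compounds shown, the group on the amide-type nitrogen is the first place where a single change moves the result beyond the scatter in this assay: phenyl in place of 2,5-dimethylphenyl gives a 3.2-fold higher number from compound 2 to compound 4 (0.51 log units; beyond the scatter). The earlier step elsewhere in the molecule, a 1.9-fold higher number from compound 1 to compound 3 (0.27 log units; within the scatter), stayed within the scatter, and here both groups keep the same six-membered aromatic ring of carbon only, so the difference lies in the methyl groups that 2,5-dimethylphenyl carries on that ring. No measurement at hand explains this step.

As far as these compounds go, it remains open whether a phenyl bearing one methyl, a chlorine or an ethyl group would read like compound 2 or like compound 4. Also open, from the compounds shown here alone, is whether the same step would appear with the ring amines of compound 1 and compound 3 in place.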